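The compounds below may be only part of what the source reports. "The series", "measured", "known", "first", "only" and "open" are said of these compounds alone.

Of the compounds shown here, three on one shared core have been measured in an assay on CHO cells for antagonist activity at transient receptor potential cation channel subfamily V member 1 (Homo sapiens), read by FLIPR; on this read-out higher numbers stand for weaker inhibition and lower numbers for stronger inhibition. Compound 1 `CC(C(=O)NCc1ccc(C(F)(F)F)nc1-c1cccc(Cl)c1)c1ccc(NS(C)(=O)=O)c(F)c1` gives 0.5 nM, compound 2 `CC(C(=O)NCc1ccc(C(F)(F)F)nc1-c1ccc(F)c(Cl)c1)c1ccc(NS(C)(=O)=O)c(F)c1` gives 0.2 nM, and compound 3 `CC(C(=O)NCc1ccc(C(F)(F)F)nc1-c1ccc(Cl)c(Cl)c1)c1ccc(NS(C)(=O)=O)c(F)c1` gives 0.9 nM, the largest of the three numbers, although compound 1 sits within the scatter of it. The steps among them were a 2.5-fold lower number from compound 1 to compound 2 (0.40 log units; beyond the scatter), a 1.8-fold higher number from compound 1 to compound 3 (0.26 log units; within the scatter) and a 4.5-fold higher number from compound 2 to compound 3 (0.65 log units; beyond the scatter). Compound 4 `CC(C(=O)NCc1ccc(C(F)(F)F)nc1-c1ccsc1)c1ccc(NS(C)(=O)=O)c(F)c1` differs from compound 3 by thiophen-3-yl in place of 3,4-dichlorophenyl on an aromatic carbon. All three measured steps alter substituents on that same ring and were modest, so a change far beyond them is not expected, although exchanging the ring itself for a five-membered aromatic ring with one hetero atom is a larger alteration and may give a somewhat higher number. The step is estimated as a 3.3-fold higher number from compound 3 to compound 4 (0.52 log units; beyond the scatter). Compound 4 is therefore expected near 3 nM, within a range from 0.8 nM to 12 nM.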

Compound 4, inhibition constant: 2 nM
For compound 4 the middle estimate is 1.5-fold (0.18 log units) above the measured one, within the range that was stated.
By their numbers in this assay, from the lowest: compound 2; then compounds 1 and 3 (each within the scatter of the next); then compound 4.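

In this assay this position accepts not only substituted phenyl groups but also thiophen-3-yl, a five-membered aromatic ring carrying no chlorine, and every exchange for it raises the number. The size of the step depends on which phenyl group leaves, with a 2.2-fold higher number from compound 3 to compound 4 (0.35 log units; beyond the scatter) and a 4.0-fold higher number from compound 1 to compound 4 (0.60 log units; beyond the scatter) and a 10-fold higher number from compound 2 to compound 4 (1.00 log units; beyond the scatter) as the three readings. Nothing at hand explains these steps. Still open, from the compounds shown here alone, is how thiophen-2-yl, furan-3-yl, pyridin-3-yl or cyclohexyl would fare here, and whether a chloro on the thiophen-3-yl ring would bring the number back down.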